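The compounds below may be only part of what the source reports. "The series", "measured", "known", "first", "only" and "open" are said of these compounds alone.

Measured compounds:
- compound 1 `CCCCCCCCO[C@@H]1O[C@@H](C)[C@H](OC(=O)CCCCC)[C@@H](O[C@@H]2O[C@@H](C)[C@H](OC(C)=O)[C@@H](O[C@@H]3O[C@@H](C)[C@H](O)[C@@H](O)[C@H]3OC(C)=O)[C@H]2OC(C)=O)[C@H]1O`: in a functional assay on Lu1 cells (Homo sapiens) for antiproliferative activity, read by MTT assay, with a stated time of 48 h (on this read-out lower numbers stand for an effect already at smaller amounts and higher numbers for an effect only at larger amounts of compound), compound 1 gives 25 uM
- compound 2 `CCCCCCCCO[C@@H]1O[C@@H](C)[C@H](OC(=O)CCCCC)[C@@H](O[C@@H]2O[C@@H](C)[C@H](OC(C)=O)[C@@H](O[C@@H]3O[C@@H](C)[C@H](OC(C)=O)[C@@H](OC(C)=O)[C@H]3O)[C@H]2OC(C)=O)[C@H]1O`: in this assay compound 2 gives 14 uM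
- compound 3 `CCCCCCCCO[C@@H]1O[C@@H](C)[C@H](OC(=O)CCCCC)[C@@H](O[C@@H]2O[C@@H](C)[C@H](OC(C)=O)[C@@H](O)[C@H]2OC(C)=O)[C@H]1O`: in this assay compound 3 reaches only the limit > 20 uM, which is not a number

Compound 2 has the lowest of the two numbers, yet its gap to compound 1 lies within the scatter, so the two cannot be told apart. For compound 3 only a limit is known (the limit of > 20 uM in this assay, at which 1 of the 3 values shown sits).

The unmeasured compound 4 `CCCCCCCCO[C@@H]1O[C@@H](C)[C@H](OC(=O)CCCCC)[C@@H](O[C@@H]2O[C@@H](C)[C@H](OC(C)=O)[C@@H](O[C@@H]3O[C@@H](C)[C@H](OC(C)=O)[C@@H](O)[C@H]3O)[C@H]2OC(C)=O)[C@H]1O` differs from compound 2 in one place: hydrogen in place of acetyl on an oxygen on a saturated carbon. Going by the values given here, no two measured compounds differ from each other in only one place, so no measured step shows what removing an acetyl does here. Compound 1 and compound 2 carry the same groups in different arrangement and sit within the scatter of each other; compound 3, with one sugar fewer, gives only a limit. In this assay the step from compound 2 to compound 4 is therefore expected to be small, with the number for compound 4 more likely to rise than to fall, and possibly reaching the limit.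

Compound 4 is estimated at 20 uM, within 8 uM to 50 uM, which means an expected step of a 1.4-fold higher number from compound 2 to compound 4 (0.15 log units; within the scatter).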

Compound 4, concentration for half-maximal effect: 25 uM
Compound 4: the middle estimate sits 1.3-fold (0.10 log units) below what was measured; the measured number falls inside the stated range.
By their numbers in this assay, from the lowest: compounds 2, 1 and 4 (each within the scatter of the next).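

Going by these compounds alone, compound 2 and compound 4 form the first pair here that differs in one place only, hydrogen in place of acetyl on an oxygen on a saturated carbon, so this change can now be read directly. In this assay the step is a 1.8-fold higher number from compound 2 to compound 4 (0.25 log units; within the scatter), which shows that at this position, acetoxy to hydroxy leaves the number within the usual spread of repeated measurements. No measurement at hand speaks to the reason for this result.

Within the data shown here, what the other acetyl groups on the core contribute remains open, as this is the only place with a step of its own. Also open, from the compounds shown here alone, is how a larger ester such as benzoyl, or an amine in place of the hydroxy, would read at this position.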